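Triazole N-aryl variation in a diaryl urea series

The compounds below may be only part of what the source reports. "The series", "measured", "known", "first", "only" and "open" are said of these compounds alone.

Two compounds of the shared core have numbers in a functional assay on HepG2 cells (Homo sapiens) for inhibition, read by MTT assay, with a stated time of 72 h; a higher number here means a weaker inhibitor, a lower number a stronger inhibitor. Compound 1 `COc1cccc(-n2cc(COc3cccc(NC(=O)Nc4ccc(Cl)c(C(F)(F)F)c4)c3)nn2)c1` gives 1310 nM in this assay. Among the compounds with values here, compound 2 `N#Cc1ccc(-n2cc(COc3cccc(NC(=O)Nc4ccc(Cl)c(C(F)(F)F)c4)c3)nn2)cc1` gives 2980 nM in this assay, the highest of the two numbers; the one step measured so far, a 2.3-fold higher number from compound 1 to compound 2 (0.36 log units; beyond the scatter), describes the swap of aryl groups on the aromatic nitrogen and is the only guide for what follows.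

Compound 3 `O=C(Nc1cccc(OCc2cn(-c3cccc(F)c3)nn2)c1)Nc1ccc(Cl)c(C(F)(F)F)c1` is unmeasured. It differs from compound 2 by 3-fluorophenyl in place of 4-cyanophenyl on an aromatic nitrogen. The step from compound 1 to compound 2 bears on this change, since both concern the aryl group on the same aromatic nitrogen; it was modest and went toward a higher number. Compound 3 carries neither the 3-methoxyphenyl of compound 1 nor the 4-cyanophenyl of compound 2, so the direction rests on a single comparison. A modest step back toward a lower number is expected, giving a 1.9-fold lower number from compound 2 to compound 3 (0.27 log units; within the scatter) as the estimated change. Compound 3 is therefore expected to give 1600 nM in this assay, within a range from 600 nM to 4500 nM.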

Compound 3, half-maximal inhibitory concentration: 2120 nM
Beside the measured number, compound 3's estimate is 1.3-fold (0.12 log units) below it; the measured number falls inside the stated range.
By their numbers in this assay, from the lowest: compounds 1, 3 and 2 (each within the scatter of the next, the first and the last beyond it).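

In this assay, 3-fluorophenyl in place of 4-cyanophenyl on the aromatic nitrogen gives a 1.4-fold lower number from compound 2 to compound 3 (0.15 log units; within the scatter), and fluoro in place of methoxy on an aromatic carbon gives a 1.6-fold higher number from compound 1 to compound 3 (0.21 log units; within the scatter). Within the data shown here, neither new step leaves the scatter, so compound 3 cannot be separated from compound 1 or compound 2, although a 2.3-fold higher number from compound 1 to compound 2 (0.36 log units; beyond the scatter) remains beyond it; at this position, the three aryl groups so far span only this narrow range of numbers. Among these compounds, no measurement of any other property accompanies these compounds, so the data offer no account of these steps.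

The step between compound 2 and compound 3 changes both the group and its place on the phenyl ring, so the compounds shown cannot separate these two changes. Also open, going by these compounds, is whether an unsubstituted phenyl, a phenyl carrying an amine or a carboxylic acid, or a saturated ring such as cyclohexyl on this nitrogen would stay within this range in this assay or move well outside it.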